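A few compounds are considered here, and "the series" means these few. Any claim that something is new, unique, unknown or untested is made for them only; others in the source may bear on it.

In a functional assay on MCF7 cells (Homo sapiens) for antiproliferative activity, read by MTT assay, with a stated time of 72 h (a lower number here means a stronger inhibitor, a higher number a weaker inhibitor), compound 1 (`NC1CCc2nc(-c3ccncc3)nc(Nc3ccc(F)cc3)c2C1`) gives 16000 nM and compound 2 (`NC1CCc2nc(-c3ccncc3)nc(Nc3cccc(F)c3)c2C1`) gives 13900 nM. Among the compounds with values here, the only measured step, a 1.2-fold lower number from compound 1 to compound 2 (0.06 log units; within the scatter), lies within the scatter, so compound 2 stands level with compound 1. Compound 3 (`N[C@@H]1CCc2nc(-c3ccncc3)nc(Nc3cccc(F)c3)c2C1`) has the same atoms and bonds as compound 2, and the difference lies only in how one centre is drawn: the two compounds have the same atoms and bonds; at least one stereo element is drawn with a configuration in one of them and without one in the other: 1 of 1 stereo elements differ; a stereocentre at a saturated ring carbon is drawn without a configuration in compound 2 and R in compound 3. A stereocentre at a saturated ring carbon is drawn without a configuration in compound 2 and R in compound 3. Within the data shown here, the one measured step concerns the fluorine on the phenyl group, so it bears only loosely on this change, and no measured pair tests the stereocentre. No step beyond the scatter is therefore expected in this assay, in either direction, although a real shift cannot be ruled out. The expected change is a 1.1-fold lower number from compound 2 to compound 3 (0.03 log units; within the scatter). For compound 3 the estimated value is 13000 nM, with an expected range from 6000 nM to 28000 nM.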

Compound 3, half-maximal inhibitory concentration: 16200 nM
Compound 3: the middle estimate sits 1.2-fold (0.10 log units) below what was measured; the measured number falls inside the stated range.
By their numbers in this assay, from the lowest: compounds 2, 1 and 3 (each within the scatter of the next).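

In this assay, the R drawing of the stereocentre at the saturated ring carbon brings a 1.2-fold higher number from compound 2 to compound 3 (0.07 log units; within the scatter), so the two compounds stand level. Within the data shown here, the earlier step spoke only to the fluorine on the phenyl group, whereas this is the first direct look at the stereocentre, and fixing it as R leaves the antiproliferative number in the same range. The comparison has one limit, as it sets a defined drawing against an undefined one, and the result has to be read with that difference in mind: the fact that one of compounds 2 and 3 is drawn with a defined configuration and the other without, at the place where they differ

Going by these compounds, how the S form behaves at this centre remains open, so the two mirror-image forms cannot yet be compared directly. On these data alone, it is also open whether an amide or a carboxylic acid in place of the amine on this ring carbon would shift the number beyond the scatter.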